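Ester in place of acetamido: expected half-life

The source may report more compounds than this note shows. Statements on the series, on what has been measured and on what is new or still open speak of the compounds shown alone.

Compound 1 `O=C(OC1CCC(CN2CCN(c3cc(=O)c4cc(C(F)(F)F)cc([N+](=O)[O-])c4s3)CC2)CC1)c1ccc(C(F)(F)F)cc1` gives 0.117 h
Compound 2 `CC(=O)NC1CCC(CN2CCN(c3cc(=O)c4cc(C(F)(F)F)cc([N+](=O)[O-])c4s3)CC2)CC1` gives > 1.55 h

In an ADME assay on cells (Hepatocyte, Homo sapiens) for metabolic stability (a lower number here means that the compound disappears faster, a higher number that the compound lasts longer), compound 1 gives a short measured half-life (0.117 h). In this assay compound 2 stands at a limit of the assay (> 1.55 h), so it has no exact number.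

Compound 3 `O=C(OC1CCC(CN2CCN(c3cc(=O)c4cc(C(F)(F)F)cc([N+](=O)[O-])c4s3)CC2)CC1)c1ccc(F)cc1` differs from compound 2 in one place, on a saturated ring carbon: ((4-fluorophenyl)carbonyl)oxy in place of acetamido (((4-fluorophenyl)carbonyl)oxy in place of acetamido on a saturated ring carbon). Among the measured compounds shown here, no measured pair shows this exact change, so any expectation is indirect. Compound 1 is the closest guide, as it also carries a carbonyl and oxygen link to an aromatic ring on that ring carbon, and its half-life is short (0.117 h). A large fall in this assay, well beyond the scatter, is therefore expected, though its true size stays uncertain while compound 2 has only a limit. The estimated change is an at least 10-fold lower number from compound 2 to compound 3 (1.01 log units; beyond the scatter) and is best read as a rough size. For compound 3 the expected half-life is 0.15 h (estimated range 0.07 h to 0.4 h).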

Compound 3, half-life: 0.0983 h
Beside the measured number, compound 3's estimate is 1.5-fold (0.18 log units) above it; measured number inside the range.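

Putting ((4-fluorophenyl)carbonyl)oxy in place of acetamido on a saturated ring carbon gives an at least 15-fold lower number from compound 2 to compound 3 (1.19 log units; beyond the scatter) in this assay, so this change now has a directly measured pair and the drop at this position is a large one. From the compounds shown here alone, the entry for compound 2 is a limit of the assay and not a number, so the true size of that step stays unknown: the limit of > 1.55 h in this assay, at which 1 of the 3 values shown sits. Fluoro in place of trifluoromethyl on an aromatic carbon gives a 1.2-fold lower number from compound 1 to compound 3 (0.08 log units; within the scatter), a step within the scatter, so this swap on the aromatic ring does not separate these two compounds in the assay.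

Going by these compounds, what stays open is which part of the entering group goes with the large drop: the oxygen link, the carbonyl or the aromatic ring, since these parts arrive together in this change. An amide link to the same 4-fluorophenyl ring, or a small acetoxy group on that ring carbon, would pull these parts apart and show whether the oxygen link or the aromatic ring goes with the short half-life.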